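This account rests on a few compounds, and the source may have more. Where it says the series, first, only, none or still open, it means among the compounds named here.

Compound 1 `Clc1cccc(CSc2nnc(-c3ccncc3)n2-c2ccccc2)c1` gives 10500 nM in a functional assay on MCF7 cells (Homo sapiens) for inhibition, read by MTT assay, with a stated time of 48 h; on this read-out higher numbers stand for weaker inhibition and lower numbers for stronger inhibition. Compound 2 `Clc1ccc(CSc2nnc(-c3ccncc3)n2-c2ccccc2)cc1` gives 13300 nM in this assay. Compound 3 `Fc1ccc(CSc2nnc(-c3ccncc3)n2-c2ccccc2)c(F)c1` gives 14100 nM in this assay.

Compound 3 stands within the scatter of both neighbours: a 1.1-fold higher number from compound 2 to compound 3 (0.03 log units; within the scatter) and a 1.3-fold higher number from compound 1 to compound 3 (0.13 log units; within the scatter). Compound 4 `O=[N+]([O-])c1cccc(CSc2nnc(-c3ccncc3)n2-c2ccccc2)c1` differs from compound 3 by 3-nitrophenyl in place of 2,4-difluorophenyl on a saturated chain carbon bound to a sulfur. Every measured step concerns this same place, and each stayed within the scatter: a 1.3-fold higher number from compound 1 to compound 2 (0.10 log units; within the scatter), a 1.3-fold higher number from compound 1 to compound 3 (0.13 log units; within the scatter), a 1.1-fold higher number from compound 2 to compound 3 (0.03 log units; within the scatter). Nothing among these three compounds points to a halogen-to-nitro exchange acting differently, so no step beyond the scatter is expected in this assay for compound 4, in either direction; the estimated step is a 1.1-fold lower number from compound 3 to compound 4 (0.04 log units; within the scatter). Compound 4 is therefore expected to give about 13000 nM, with a range from 6000 nM to 28000 nM.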

Compound 4, half-maximal inhibitory concentration: 18300 nM
Compound 4: middle estimate off by 1.4-fold (0.15 log units), on the low side; low and high end bracket the measured number.
By their numbers in this assay, from the lowest: compounds 1, 2, 3 and 4 (each within the scatter of the next).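

Within the data shown here, the nitro group, absent from the earlier compounds, brings no step beyond the scatter at this place in this assay: there is a 1.3-fold higher number from compound 3 to compound 4 (0.11 log units; within the scatter) and a 1.4-fold higher number from compound 2 to compound 4 (0.14 log units; within the scatter) and a 1.7-fold higher number from compound 1 to compound 4 (0.24 log units; within the scatter) for the direct exchange of nitro for chloro on an aromatic carbon. The range of groups that leave the number within the scatter thus extends from chloro and fluoro substituents to a nitro substituent.

The compounds shown leave open whether an amine, a carboxylic acid or a longer chain at this place would produce a step beyond the scatter. No measurement given here explains why these numbers stay so close.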